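From 4-ethylpiperazin-1-yl to 4-methylpiperazin-1-yl

A few compounds are considered here, and "the series" means these few. Any claim that something is new, unique, unknown or untested is made for them only; others in the source may bear on it.

Of the compounds shown here, two have numbers so far in an ADME assay on microsomes from liver (Mus musculus) for metabolic stability, read by LC-MS, with a stated time of 10 min, tested at 0.5 uM (a higher number here means that more of the compound is left, a lower number that less of the compound is left), and they sit well apart. Compound 1 (`CN1CCN(CCCN(C[C@H]2Cc3ccccc3CN2C)[C@H]2CCCc3cccnc32)CC1`) gives 43% and compound 2 (`CCN1CCN(CCCN(C[C@H]2Cc3ccccc3CN2)[C@H]2CCCc3cccnc32)CC1`) gives 19% under the same conditions. Compound 2 therefore holds the lower of the two numbers, with a gap to compound 1 that lies beyond the scatter.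

Compound 3 (`CN1CCN(CCCN(C[C@H]2Cc3ccccc3CN2)[C@H]2CCCc3cccnc32)CC1`) is still unmeasured. Its difference from compound 2 is hydrogen in place of methyl on a saturated chain carbon bound to an amine nitrogen in a ring in a single place, namely hydrogen in place of methyl on a saturated chain carbon bound to an amine nitrogen in a ring. Going by the values given here, no measured pair shows this change alone, so the expectation is loose. A small upward step is expected, perhaps none beyond the scatter, and the estimated step is a number 5 percentage points higher from compound 2 to compound 3 (within the scatter) in size. The reference is compound 2 at 19% as the measured compound differing in one place only. Compound 3 is estimated at 24% with an expected range from 12% to 38% in this measurement.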

Compound 3, percent of the compound remaining: 53%
The estimate for compound 3 lay 29 percentage points below the measured number; measured number outside the range, above it.
By their numbers in this assay, from the lowest: compound 2; then compounds 1 and 3 (each within the scatter of the next).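

In this assay, going by these compounds alone, the change from 4-ethylpiperazin-1-yl to 4-methylpiperazin-1-yl, read alone for the first time, gives a number 34 percentage points higher from compound 2 to compound 3 (beyond the scatter) and so shows that this position is sensitive to a single carbon. Within the data shown here, the other change, hydrogen in place of methyl on an amine nitrogen in a ring, gives a number 10 percentage points higher from compound 1 to compound 3 (within the scatter) and so shows no step that can be told from repeated measurement at that place. Nothing at hand explains the size of the step from ethyl to methyl.

Going by these compounds, whether a longer chain such as propyl, or a small ring such as cyclopropyl, on the same piperazine nitrogen would follow ethyl remains open. So does the reading with plain hydrogen there, and whether the two places act independently of each other.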